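From Ethyl to Methoxycarbonyl on a Shared Core

This account rests on a few compounds, and the source may have more. Where it says the series, first, only, none or still open, it means among the compounds named here.

Three compounds have numbers in a functional assay on PPC-1 cells (Homo sapiens) for cytotoxicity, read by sulforhodamine B assay, with a stated time of 48 h (a higher number here means a weaker inhibitor, a lower number a stronger inhibitor), so far. Compound 1 (`COc1ccc(-c2nc(C(=O)c3cc(OC)c(OC)c(OC)c3)cs2)cc1OC`) gives 56 nM in this test. Compound 2 (`CCc1ccc(-c2nc(C(=O)c3cc(OC)c(OC)c(OC)c3)cs2)cc1`) gives 22 nM on the same core. Compound 3 (`CCCCCCCCCCCCCCCCNC(=O)[C@@H]1CSC(c2ccc(NC(C)=O)cc2)N1`) has a different core and gives 400 nM here. Compound 2 therefore has the lowest number of the three, and its gaps to both others lie beyond the usual scatter.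

Compound 4 (`COC(=O)c1ccc(-c2nc(C(=O)c3cc(OC)c(OC)c(OC)c3)cs2)cc1`) keeps the core of compound 2 but carries methoxycarbonyl in place of ethyl on an aromatic carbon, para to a large group (methoxycarbonyl in place of ethyl on an aromatic carbon). Among the measured compounds shown here, no measured pair shows this change directly, so any forecast is loose. For the measured compounds named here, compound 1, at 56 nM with other substitution on that core, offers the only hint that such changes can raise the number. A rise beyond the scatter, towards weaker inhibition, is the expected direction, and the estimated move is moderate: a 5.5-fold higher number from compound 2 to compound 4 (0.74 log units; beyond the scatter) is the step anticipated. In this assay compound 4 is expected at 120 nM with 35 nM to 500 nM as its estimated range.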

Compound 4, half-maximal inhibitory concentration: > 20000 nM
Compound 4 was reported as a limit; the forecaster's own chance of this, stated with the estimate: 5%; at least 160-fold (2.22 log units) between middle value and limit.
By their numbers in this assay, from the lowest: compound 2; then compound 1; then compound 3. At a limit, above all of these: compound 4.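

In this assay compound 4 gives > 20000 nM, which is a limit of the assay and not a number. Placing methoxycarbonyl in place of ethyl on an aromatic carbon, para to a large group, gives the first direct reading of a single change at this position on the shared core, and it produces an at least 900-fold higher number from compound 2 to compound 4 (2.95 log units; beyond the scatter), so what sits here is far from indifferent in this test. The true size of the step remains unfixed, as only its lower bound can be read: the limit of > 20000 nM in this assay, at which 1 of the 4 values shown sits.

Nothing shown says why the change has so large an effect, or which part of the methoxycarbonyl group matters. From the compounds shown here alone, it also remains open how a carboxylic acid, an amide, an amine or a longer chain such as propyl would read at this position.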